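This account rests on a few compounds, and the source may have more. Where it says the series, first, only, none or still open, it means among the compounds named here.

This piece follows one change made to compound 1 `CC(=O)NC1=CS(=O)(=O)O[C@@]12[C@@H](CO[Si](C)(C)C(C)(C)C)O[C@@H](n1cc(C)c(=O)n(C)c1=O)[C@@H]2O[Si](C)(C)C(C)(C)C` and asks what it should do to tolerance of the compound in a functional assay on HEL cells (Homo sapiens) for cytotoxicity, read by microscopy; a lower number here means that less compound is tolerated, a higher number that more compound is tolerated. Compound 1 gives >= 80000 nM, which is a limit of the assay and not a number. Two relatives share its core. Compound 2 `Cc1cn([C@@H]2O[C@H](CO[Si](C)(C)C(C)(C)C)[C@@]3(OS(=O)(=O)C=C3NCC(=O)OCc3ccccc3)[C@H]2O[Si](C)(C)C(C)(C)C)c(=O)n(C)c1=O` carries (benzyloxycarbonyl)methyl in place of acetyl on an amine nitrogen; in this assay compound 2 gives >= 400000 nM, again a limit and not a number. Compound 3 `Cc1cn([C@@H]2O[C@H](CO[Si](C)(C)C(C)(C)C)[C@@]3(OS(=O)(=O)C=C3NCC(=O)C(=O)O)[C@H]2O[Si](C)(C)C(C)(C)C)c(=O)n(C)c1=O` carries (carboxycarbonyl)methyl in place of acetyl on an amine nitrogen, and in this assay compound 3 gives 400000 nM. The step that the two limits leave unreadable from compound 1 to compound 2 and the step that the limit leaves unreadable from compound 1 to compound 3 therefore cannot be sized, and the step of a number no higher from compound 2 to compound 3 (the limit leaves the size open) is open as well. Compound 4 `Cc1cn([C@@H]2O[C@H](CO[Si](C)(C)C(C)(C)C)[C@@]3(OS(=O)(=O)C=C3NC(=O)c3ccccc3)[C@H]2O[Si](C)(C)C(C)(C)C)c(=O)n(C)c1=O` differs from compound 1 as follows: phenyl in place of methyl on a carbonyl carbon. Going by the values given here, no measured step involves a phenyl at this place, and every step between the measured compounds is hidden by the limits the limit of >= 400000 nM in this assay, at which 1 of the 3 values shown sits, and (the limit of >= 80000 nM in this assay, at which 1 of the 3 values shown sits). For compound 4 the expected step is a step that the limit leaves unreadable from compound 1 to compound 4, which means no change beyond the scatter. Compound 4 is estimated at 200000 nM, between 80000 nM and 400000 nM, and most likely reported again only as a limit.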

Compound 4, minimum cytotoxic concentration: >= 3200 nM
Compound 4: only a limit was reported (the forecaster's own chance of this, stated with the estimate: 70%); the middle value does not contradict the limit.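

In this assay compound 4 gives >= 3200 nM, which is a limit and not a number. Its steps from compound 1, compound 2 and compound 3 cannot be read. The compounds shown leave open whether phenyl in place of methyl on a carbonyl carbon changes the tolerated concentration at all, and in which direction.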